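Swapping one phenyl group on a shared core

A few compounds are considered here, and "the series" means these few. Any claim that something is new, unique, unknown or untested is made for them only; others in the source may bear on it.

compound 1 `CCCOC(=O)N1N=C(c2ccc(OC)cc2)CC1c1cc(OC)c(OC)c(OC)c1` gives > 10000 nM (a limit)
compound 2 `CCOc1cccc(C2=NN(C(=O)OC)C(c3cc(OC)c(OC)c(OC)c3)C2)c1` gives 8360 nM (a number)

Both values come from a functional assay on HepG2 cells (Homo sapiens) for antiproliferative activity, read by MTT assay, with a stated time of 48 h (on this read-out higher numbers stand for weaker inhibition of growth and lower numbers for stronger inhibition of growth), and they are all that has been measured so far. Compound 1 shows > 10000 nM and that value is a limit, not a number. Within the data shown here, compound 2, at 8360 nM, holds the only true number, so it has no other number to be ranked against.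

Compound 3 `COC(=O)N1N=C(c2ccc(OC)c(OC)c2)CC1c1cc(OC)c(OC)c(OC)c1` has not yet been measured. It keeps the core of compound 2 and changes one group (3,4-dimethoxyphenyl in place of 3-ethoxyphenyl on a carbon with a double bond to nitrogen) with 3,4-dimethoxyphenyl in place of 3-ethoxyphenyl on a carbon with a double bond to nitrogen.

Among the measured compounds shown here, no two measured compounds differ in just one place, so no measured step can guide this change. The starting point is compound 2 at 8360 nM and in this assay the expectation is no shift beyond the usual scatter, with no firm direction. The estimated change a 1.3-fold lower number from compound 2 to compound 3 (0.11 log units; within the scatter) is expected to stay small. Compound 3 is estimated at 6500 nM with an expected range from 2000 nM to 18000 nM in this read-out.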

Compound 3, concentration for 50% growth inhibition: 4210 nM
The estimate for compound 3 lay 1.5-fold (0.19 log units) above the measured number; the measured number falls inside the stated range.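

In this assay, among these compounds, placing 3,4-dimethoxyphenyl in place of 3-ethoxyphenyl on the carbon with a double bond to nitrogen gives a 2.0-fold lower number from compound 2 to compound 3 (0.30 log units; within the scatter), the first step that can be read at this position. On this read-out the two groups cannot be told apart, with the methoxycarbonyl group and the rest of the shared core kept the same. Compound 1 gives > 10000 nM, which is a limit and not a number, the steps to it cannot be read, and nothing shown points to a cause for what is seen at this position.

The compounds shown leave open whether a group of another kind at this position, such as a pyridine ring or a phenyl ring carrying an amine or a carboxylic acid, would read differently from compound 3 at 4210 nM. They also leave open what a plain phenyl group would give here, and what a longer chain on the ester would give alongside the 3,4-dimethoxyphenyl group.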